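This account rests on a few compounds, and the source may have more. Where it says the series, first, only, none or still open, it means among the compounds named here.

In a functional assay on MOLT-4 cells (Homo sapiens) for inhibition, read by MTT assay, with a stated time of 72 h (on this read-out lower numbers stand for stronger inhibition and higher numbers for weaker inhibition), compound 1 (`COc1cc(NC(C)CCCNC(=O)Nc2ccc(Cl)cc2)c2ncccc2c1`) gives 24000 nM, compound 2 (`COc1cc(NC(C)CCCNC(=O)NNC(=O)Nc2cccc(Cl)c2)c2ncccc2c1`) gives 93000 nM and compound 3 (`COc1cc(NC(C)CCCNC(=O)NNC(=O)Nc2ccc(O)cc2)c2ncccc2c1`) gives 104000 nM. Compound 3 thus sits level with compound 2, the gap being a 1.1-fold higher number from compound 2 to compound 3 (0.05 log units; within the scatter), and that swap of aryl groups stays within the scatter. Compound 4 (`COc1cc(NC(C)CCCNC(=O)Nc2ccc(O)cc2)c2ncccc2c1`) changes compound 3 at one place: 4-hydroxyphenyl in place of ((4-hydroxyphenyl)carbamoyl)amino on an amide-type nitrogen. Two measured steps bring in a carbamoylamino group of this kind, a 3.9-fold higher number from compound 1 to compound 2 (0.59 log units; beyond the scatter) and a 4.3-fold higher number from compound 1 to compound 3 (0.64 log units; beyond the scatter), and both lie beyond the scatter. Compound 4 reverses that kind of change, so a modest step towards a lower number is expected in this assay. The expected change is a 3.5-fold lower number from compound 3 to compound 4 (0.54 log units; beyond the scatter). For compound 4 the estimated value is 30000 nM, with an expected range of 12000 nM to 75000 nM.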

Compound 4, half-maximal inhibitory concentration: 21000 nM
The estimate for compound 4 lay 1.4-fold (0.15 log units) above the measured number; measured number inside the range.
By their numbers in this assay, from the lowest: compounds 4 and 1 (each within the scatter of the next); then compounds 2 and 3 (each within the scatter of the next).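

In this assay, taking out the carbamoylamino unit gives a 5.0-fold lower number from compound 3 to compound 4 (0.69 log units; beyond the scatter), and against the 3-chlorophenyl partner the change gives a 4.4-fold lower number from compound 2 to compound 4 (0.65 log units; beyond the scatter), so the penalty seen on adding this unit also reverses when it is removed. With the unit absent, hydroxy in place of chloro on the aromatic carbon gives a 1.1-fold lower number from compound 1 to compound 4 (0.06 log units; within the scatter), so the aryl substituent does not separate these two compounds either. No measured evidence explains these steps. From the compounds shown here alone, whether an amine or a carboxylic acid on that aromatic ring would lower the number remains open.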